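Ethoxy in place of fluoro: compound 3 to compound 4

A few compounds are considered here, and "the series" means these few. Any claim that something is new, unique, unknown or untested is made for them only; others in the source may bear on it.

Three compounds of the series have a number in a functional assay on Hep 3B2 cells (Homo sapiens) for antiproliferative activity, read by MTT assay, with a stated time of 24 h, tested at 11.11 ug/mL; on this read-out higher numbers stand for a stronger effect at the one concentration tested and lower numbers for a weaker effect. Compound 1 `Cc1ccc2nc(C(=O)Nc3c(F)cc(-c4cccc(F)c4)cc3F)c(C)c(O)c2c1` gives 25.5%. Compound 2 `CCc1ccc2nc(C(=O)Nc3c(F)cc(-c4cccc(F)c4)cc3F)c(C)c(O)c2c1` gives 46.3%. Compound 3 `Cc1c(C(=O)Nc2c(F)cc(-c3cccc(F)c3)cc2F)nc2ccc(F)cc2c1O` gives 31.3%, the second highest of the three numbers; compound 1 lies within the scatter of it, while compound 2 lies beyond it.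

Compound 4 `CCOc1ccc2nc(C(=O)Nc3c(F)cc(-c4cccc(F)c4)cc3F)c(C)c(O)c2c1` differs from compound 3 by ethoxy in place of fluoro on an aromatic carbon. Within the data shown here, two measured steps concern the same aromatic carbon. The step of a number 5.8 percentage points higher from compound 1 to compound 3 (within the scatter) stays within the scatter, so methyl and fluoro there are not told apart. The step of a number 15 percentage points lower from compound 2 to compound 3 (beyond the scatter) is beyond the scatter, so ethyl there gave the higher number. Ethoxy, like ethyl, is a chain group rather than a single halogen, and a change of similar direction is expected, tempered because the change methyl to fluoro a number 5.8 percentage points higher from compound 1 to compound 3 (within the scatter) showed nothing. For compound 4 a modest rise is expected, about a number 8.7 percentage points higher from compound 3 to compound 4 (within the scatter). Compound 4 is therefore estimated at 40%, within 24% to 56%.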

Compound 4, a percentage reported as inhibition, at one concentration (the size of the read-out at that concentration, not a potency): 2.03%
The estimate for compound 4 lay 38 percentage points above the measured number, outside the stated range (below it).
By their numbers in this assay, from the lowest: compound 4; then compounds 1 and 3 (each within the scatter of the next); then compound 2.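

In this assay, among these compounds, ethoxy is the first group on this aromatic carbon to give a number below all the others: a number 29.3 percentage points lower from compound 3 to compound 4 (beyond the scatter), a number 23.5 percentage points lower from compound 1 to compound 4 (beyond the scatter), and a number 44.3 percentage points lower from compound 2 to compound 4 (beyond the scatter). The last of these is the largest step in the series and separates two chains of similar kind, so the earlier link between a chain on this carbon and a higher number does not hold for ethoxy, the compound that goes against it. On this carbon, the series now spans its full range through the choice between ethyl and ethoxy alone.

The compounds shown do not tell whether the low number goes with the linking oxygen or with the ethoxy group as a whole; methoxy or a longer chain such as propyl on this carbon would bear on that. No measurement at hand bears on the reason for the gap between ethyl and ethoxy.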